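The compounds below may be only part of what the source reports. "The series", "measured", "known", "first", "only" and "open" are said of these compounds alone.

Series notes. The shared core of compound 3 `Fc1cccc(-c2cc(-c3cnn(C4CCNCC4)c3)on2)c1Cl` is also that of compound 2 `c1ccc(-c2cc(-c3cnn(C4CCNCC4)c3)on2)cc1` and, with an added methyl, of compound 1 `Cc1c(-c2cc(-c3ccccc3Cl)no2)cnn1C1CCNCC1`. In an assay on isolated protein for positive allosteric modulation of Neuronal acetylcholine receptor; alpha4/beta2 (Homo sapiens) (on this read-out higher numbers stand for an effect only at larger amounts of compound and lower numbers for an effect already at smaller amounts), compound 1 gives 18 nM, compound 2 gives 100000 nM and compound 3 gives 230 nM. Within these three numbers compound 3 stands second; compound 1 lies beyond the scatter on the lower side and compound 2 far beyond it on the higher side. Going by the values given here, the one measured step with a single change is a 430-fold lower number from compound 2 to compound 3 (2.64 log units; beyond the scatter).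

Compound 4 `c1nn(C2CCNCC2)cc1-c1cc(C2CCCCC2)no1` is not yet measured. Its change from compound 3 is cyclohexyl in place of 2-chloro-3-fluorophenyl on an aromatic carbon. Among the compounds with values here, no measured step removes the aromatic ring at this place, so the only guide is that compound 2, with a plain phenyl, gives 100000 nM, a number far higher than that of compound 3. For compound 4 a large rise in number is therefore expected, a 130-fold higher number from compound 3 to compound 4 (2.12 log units; beyond the scatter). Compound 4 is estimated at 30000 nM, with a range from 3000 nM to 100000 nM, and a limit reading is quite possible.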

Compound 4, half-maximal effective concentration: 4600 nM
Estimate against measurement, compound 4: 6.5-fold (0.81 log units) above; the range from low to high includes it.
By their numbers in this assay, from the lowest: compound 1; then compound 3; then compound 4; then compound 2.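

On the aromatic carbon next to the ring nitrogen, an aromatic ring is not needed for a lower number in this assay: non-aromatic cyclohexyl reads well below plain phenyl (a 22-fold lower number from compound 2 to compound 4 (1.34 log units; beyond the scatter)). It does not match the substituted aromatic ring, however (a 20-fold higher number from compound 3 to compound 4 (1.30 log units; beyond the scatter)), so the order at this place runs 2-chloro-3-fluorophenyl, then cyclohexyl, then phenyl, and aromatic or non-aromatic alone does not decide the number. Nothing at hand gives a reason for either step.

On these data alone, what the chlorine and the fluorine each contribute on the phenyl ring remains open. As far as these compounds go, it is also open whether cyclopentyl, a tert-butyl group or a cyclohexyl ring bearing a hydroxyl or an amine would read nearer to compound 3 or to compound 2 at this place.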